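The compounds below may be only part of what the source reports. "The series", "measured", "known", "first", "only" and "open" are said of these compounds alone.

Measured compounds:
compound 1 `O=C(O)c1cnc2cc(O)ccc2c1O`: 490000 nM
compound 2 `O=C(O)c1cnc2cc(OCCOc3ccc(Br)cc3)ccc2c1O`: 5130 nM
compound 3 `O=C(O)c1cnc2cc(OCCOc3ccccc3)ccc2c1O`: 60300 nM

In an assay on isolated protein with malate dehydrogenase, mitochondrial (Sus scrofa) as the target (on this read-out lower numbers stand for stronger inhibition and higher numbers for weaker inhibition), compound 1 gives 490000 nM, the highest of the three numbers: compound 3 gives 60300 nM and compound 2 gives 5130 nM, both beyond the scatter below compound 1. For the measured compounds named here, the one step between compounds differing in a single place is a 12-fold higher number from compound 2 to compound 3 (1.07 log units; beyond the scatter). Compound 4 `NS(=O)(=O)c1ccc2c(O)c(C(=O)O)cnc2c1` is not yet measured. Its change from compound 1 is sulfamoyl in place of hydroxy on an aromatic carbon.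

None of the measured steps touches the hydroxy itself, so the step in this assay from hydroxy to sulfamoyl is not directly shown. What the data do show is that this hydroxy can be replaced with no loss and with a strong gain in compounds 2 and 3, while the measured step of a 12-fold higher number from compound 2 to compound 3 (1.07 log units; beyond the scatter) concerns only the far end of such a chain. For compound 4 a moderate drop in number is therefore expected, a 2.5-fold lower number from compound 1 to compound 4 (0.39 log units; beyond the scatter), with wide uncertainty. Compound 4 is estimated at 200000 nM, between 50000 nM and 600000 nM.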

Compound 4, half-maximal inhibitory concentration: 955000 nM
For compound 4 the middle estimate is 4.8-fold (0.68 log units) below the measured one, outside the stated range (above it).
By their numbers in this assay, from the lowest: compound 2; then compound 3; then compounds 1 and 4 (each within the scatter of the next).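

In this assay, the direct replacement of hydroxy by sulfamoyl on this aromatic carbon gives a 1.9-fold higher number from compound 1 to compound 4 (0.29 log units; within the scatter), so the two compounds cannot be told apart on this read-out. This is the first single-place step shown for the hydroxy itself, whereas the earlier step concerned only a bromo or hydrogen on a separate aromatic ring. Here, a swap to a group with more heavy atoms, and with the same net charge, leaves the result within the usual scatter, and nothing available accounts for this.

Going by these compounds, whether an amine, a methoxy or a carboxylic acid on the same aromatic carbon would also stay within the scatter of compound 1 remains open. So does whether a longer chain attached through the sulfamoyl would produce a step beyond it.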